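The source may report more compounds than this note shows. Statements on the series, on what has been measured and on what is new or still open speak of the compounds shown alone.

Of the compounds shown here, three of a shared core have been tested in a functional assay on Hs-578T cells (Homo sapiens) for cytotoxicity, read by sulforhodamine B assay, with a stated time of 48 h, tested at 0.01 uM; a lower number here means a stronger effect, a higher number a weaker effect of the compound at the concentration tested. Compound 1 `COc1cc(C)cc(-c2c(-c3ccnc(-c4ccc(C(C)=O)cc4)c3)cnn2CC#N)c1` gives 98% in this assay. Compound 2 `COc1cc(C)cc(-c2nn(CC#N)cc2-c2ccc(-c3cccc(C(C)=O)c3)nc2)c1` gives 100%. Compound 3 `Cc1cc(O)cc(-c2nn(CC#N)cc2-c2ccnc(-c3ccc(Oc4ccccc4)cc3)c2)c1` gives 91% in this assay. Among the measured compounds shown here, all three readings are high, which at this concentration means a weak effect on the cells, and each of them sits within the usual scatter of the other two, so no compound can be set apart from the others on these numbers.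

Compound 4 `Cc1cc(O)cc(-c2nn(CC#N)cc2-c2ccnc(-c3ccc(N(C)C)cc3)c2)c1` has not yet been measured. It differs from compound 3 in one place: dimethylamino in place of phenoxy on an aromatic carbon. For the measured compounds named here, no pair of measured compounds differing in a single place is available, so nothing can be said from the data about how large a step such a change might bring. Going by the values given here, with no step to lean on, the expectation for compound 4 is a reading like that of compound 3, and the step of a number 4 percentage points higher from compound 3 to compound 4 (within the scatter) is expected to be none beyond the scatter. Compound 4 is therefore estimated at 95% in this assay, within a range from 82% to 105%.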

Compound 4, a percentage reported as activity, at one concentration (the size of the read-out at that concentration, not a potency): 95%
Estimate against measurement, compound 4: no gap at the digits printed; the measured number falls inside the stated range.
By their numbers in this assay, from the lowest: compounds 3, 4, 1 and 2 (each within the scatter of the next).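

Among the compounds shown here, this pair is the first in the set that differs in one place only, and putting dimethylamino in place of phenoxy on an aromatic carbon, para to a large group, gives a number 4 percentage points higher from compound 3 to compound 4 (within the scatter) in this assay. So at this place, the six-membered aromatic ring of phenoxy can give way to a smaller group with no ring without the reading leaving the scatter, and both compounds still read high, which here means a weak effect on the cells at the concentration tested. Nothing available explains this result.

From the compounds shown here alone, it remains open whether a carboxylic acid, a primary amine or a longer alkyl chain at this place would shift the reading beyond the scatter. With a single step, it is also unclear whether this result would hold on the other compounds of the series.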